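The source may hold more compounds than are shown below. What is called first, only, known or untested is meant among the compounds shown, and "the series" means these compounds.

Of the compounds shown here, two with the same core have been tested so far in an ADME assay on Jurkat cells (Homo sapiens) for cytotoxicity; a lower number here means a stronger inhibitor, a higher number a weaker inhibitor. Compound 1 `Cc1nc(-c2ccccc2)sc1C(=O)N[C@H](/C=C/S(=O)(=O)c1ccccc1)CCc1ccccc1` gave no exact number, only a limit of > 100000 nM. Among the compounds with values here, compound 2 `Cc1nc(-c2cccnc2)sc1C(=O)N[C@H](/C=C/S(=O)(=O)c1ccccc1)CCc1ccccc1` gave 98000 nM, the only exact number available, so there is no measured series against which to rank it. The next compound keeps everything except one ring. In compound 3 `Cc1nc(-c2cnccn2)sc1C(=O)N[C@H](/C=C/S(=O)(=O)c1ccccc1)CCc1ccccc1`, the change is pyrazin-2-yl in place of pyridin-3-yl on an aromatic carbon. That carbon lies on a five-membered aromatic ring with 1 nitrogen and 1 sulfur.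

The closest evidence comes from the same place in the molecule, where pyridin-3-yl took the place of phenyl. That measured step was an at least 1.0-fold lower number from compound 1 to compound 2 (0.00 log units; that floor lies within the scatter), which does not go beyond the scatter. On that single step, no change beyond the scatter is expected in this assay, in either direction. The expected step is a 1.0-fold higher number from compound 2 to compound 3 (0.01 log units; within the scatter). Compound 3 is estimated at 100000 nM, with an expected range of 50000 nM to 200000 nM. The assay may also report only a limit, as it did for compound 1.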

Compound 3, half-maximal inhibitory concentration: > 100000 nM
Compound 3: no number, only a limit; the forecaster's own chance of this, stated with the estimate: 55%; the middle value sits exactly at the limit.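

Pyrazin-2-yl in place of pyridin-3-yl on this carbon, next to the ring nitrogen and next to the ring sulfur, gives an at least 1.0-fold higher number from compound 2 to compound 3 (0.00 log units; that floor lies within the scatter) in this assay, so a ring with 2 hetero atoms did not bring the number down beyond the scatter compared with a ring with 1 hetero atom. Compound 3 gives only a limit, > 100000 nM, and not an exact number. The step between compound 1 and compound 3 cannot be read, as both values are limits, and most of this small series now rests on such values: the limit of > 100000 nM in this assay, at which 2 of the 3 values shown sit.

From the compounds shown here alone, all three groups on this carbon are six-membered aromatic rings, so it remains open whether a different kind of group there, such as an amine, a morpholine or a carboxylic acid, would give a clearly lower number in this assay. The rest of the molecule is the same in all three compounds, which leaves open what a change elsewhere, such as a longer chain in place of the phenylethyl arm, would do.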